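The source may report more compounds than this note shows. Statements on the series, on what has been measured and on what is new or still open speak of the compounds shown alone.

Of the compounds shown here, three have so far been measured in a functional assay on MCF7 cells (Homo sapiens) for antiproliferative activity; a lower number here means a stronger inhibitor, a higher number a weaker inhibitor. Compound 1 `CCCCn1c(Cc2c(Br)c(OC)c(OC)c(OC)c2Br)nc2c(N)ncnc21` gives 30200 nM, compound 2 `COc1cc(Cc2nc3c(N)ncnc3n2CC2CCCCC2)cc(OC)c1OC` gives 39800 nM, and compound 3 `COc1cc(Cc2nc3c(N)nc(F)nc3n2CCOC(C)C)c(Cl)c(OC)c1OC` gives 5370 nM. Compound 2 has the highest of the three numbers; its gap to compound 1 lies within the scatter, while its gap to compound 3 lies beyond it. The next compound, compound 4 `COCCn1c(Cc2cc(OC)c(OC)c(OC)c2)nc2c(N)ncnc21`, differs from compound 2 in one place: methoxymethyl in place of cyclohexyl on a saturated chain carbon bound to an aromatic nitrogen. Going by the values given here, no pair of measured compounds differs in just one place, so no measured step guides the expectation. In this assay the step of a 1.6-fold lower number from compound 2 to compound 4 (0.20 log units; within the scatter) is expected to be small, toward a lower number, and quite possibly not beyond the scatter. Compound 4 is expected to give about 25000 nM, within a range from 8000 nM to 80000 nM.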

Compound 4, half-maximal inhibitory concentration: 64600 nM
Beside the measured number, compound 4's estimate is 2.6-fold (0.41 log units) below it; the measured number falls inside the stated range.
By their numbers in this assay, from the lowest: compound 3; then compounds 1, 2 and 4 (each within the scatter of the next, the first and the last beyond it).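

In this assay, going by these compounds alone, the exchange of methoxymethyl for cyclohexyl on a saturated chain carbon bound to an aromatic nitrogen gives the first step that can be read at this position: a 1.6-fold higher number from compound 2 to compound 4 (0.21 log units; within the scatter). Removing the carbon-only ring and bringing in an open chain with a hydrogen-bond acceptor therefore does not separate these two compounds. Nothing available explains this result.

Going by these compounds, whether an amine, a carboxylic acid or a longer chain at this place would move the number beyond the scatter remains open. So does whether the same exchange would read alike with the other substituents of compound 3.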